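This account rests on a few compounds, and the source may have more. Where it says the series, first, only, none or still open, it means among the compounds named here.

This account follows the step from compound 3 to compound 4 in an ADME assay on CCRF-CEM cells (Homo sapiens) for cytotoxicity; on this read-out lower numbers stand for higher toxicity in this test and higher numbers for lower toxicity in this test. The compounds share a nucleoside core that carries a disulfide, and the group beyond that disulfide varies. Compound 1, with the structure `CSS[C@H]1C[C@H](n2ccc(N)nc2=O)O[C@@H]1CO`, gives 111000 nM in this assay. Compound 2, with the structure `O=c1nc(O)ccn1[C@H]1C[C@H](SS[C@H]2C[C@H](n3ccc(O)nc3=O)O[C@@H]2CO)[C@@H](CO)O1`, is reported only as a limit of this assay, >= 250000 nM, and not as a number; this is recorded in the note (the limit of >= 250000 nM in this assay, at which 1 of the 3 values shown sits). Compound 3, with the structure `Cc1cn([C@H]2C[C@H](SSC(Cl)(Cl)Cl)[C@@H](CO)O2)c(=O)[nH]c1=O`, gives 103000 nM in this assay. Among the values that are numbers, compound 3 and compound 1 lie within the scatter of each other, so no order can be read between them.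

Compound 4, with the structure `Cc1cn([C@H]2C[C@H](SSc3ccccc3[N+](=O)[O-])[C@@H](CO)O2)c(=O)[nH]c1=O`, has not yet been measured in this assay. It differs from compound 3 in one place: 2-nitrophenyl in place of trichloromethyl on a sulfur. Among the compounds with values here, no step between two measured compounds changes this same group, so the size of the step cannot be taken from a measured pair. Given that the measured numbers of compound 1 and compound 3 sit close together, the step from compound 3 to compound 4 is expected to be small, perhaps a modest move toward a lower number, a 1.3-fold lower number from compound 3 to compound 4 (0.11 log units; within the scatter). On that basis compound 4 is estimated at 80000 nM in this assay, with a range from 30000 nM to 250000 nM.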

Compound 4, half-maximal cytotoxic concentration: 18500 nM
Beside the measured number, compound 4's estimate is 4.3-fold (0.64 log units) above it; the whole stated range lies above it.
By their numbers in this assay, from the lowest: compound 4; then compounds 3 and 1 (each within the scatter of the next). At a limit, above all of these: compound 2.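

In this assay, the group on a sulfur whose other neighbour is sulfur proves able to move the read-out: with 2-nitrophenyl in place of trichloromethyl, the number falls, a 5.6-fold lower number from compound 3 to compound 4 (0.75 log units; beyond the scatter), and this step lies beyond the scatter. Within the data shown here, the earlier compounds offered no pair differing in one place, so this is the first direct reading of what this position can do on the shared core, and it shows that the group beyond the disulfide is not a neutral passenger in this test. Nothing given here bears on why the step has this size.

The compounds shown leave open whether the aromatic ring or the nitro group carries the step, as 2-nitrophenyl brings both at once, and a plain phenyl or a phenyl bearing an amine in the same place would separate the two. Also open, going by these compounds, is how a longer alkyl chain or a carboxylic acid on this sulfur would read, and whether the same exchange gives a step of similar size on the core of compound 1.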